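This account rests on a few compounds, and the source may have more. Where it says the series, first, only, none or still open, it means among the compounds named here.

Measured in a functional assay on LoVo cells (Homo sapiens) for antiproliferative activity, read by MTT assay, with a stated time of 72 h; on this read-out higher numbers stand for weaker inhibition and lower numbers for stronger inhibition:
- Compound 1 `Cc1noc(C)c1-c1nn(Cc2ccc(C(=O)NC3CC3)cc2)c(=O)c2ccccc12`: > 100000 nM, a limit of the assay
- Compound 2 `Cc1noc(C)c1-c1nn(Cc2ccc(C(=O)N3CCCCC3)cc2)c(=O)c2ccccc12`: > 100000 nM, a limit of the assay
- Compound 3 `Cc1noc(C)c1-c1nn(Cc2ccc(C(=O)NC3CC(C)(C)N([O])C(C)(C)C3)cc2)c(=O)c2ccccc12`: 41200 nM

In this assay, within the data shown here, compound 3 is the only member of the series with a number, at 41200 nM. The other two values are not numbers: they are the limit of > 100000 nM in this assay, at which 2 of the 3 values shown sit.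

Compound 4 `Cc1noc(C)c1-c1nn(Cc2ccc(C(=O)NC3CCCC3)cc2)c(=O)c2ccccc12` is the next entry, with cyclopentyl on the amide-type nitrogen: a group of 5 heavy atoms (5 carbon; one five-membered non-aromatic ring of carbon only) in place of a group of 11 heavy atoms (9 carbon, 1 nitrogen, 1 oxygen; one six-membered non-aromatic ring with 1 hetero atom), on an amide-type nitrogen. It gives up the group of compound 3 for an all-carbon ring.

Among the measured compounds shown here, two measured steps bear on this change when read in reverse: an at least 2.4-fold lower number from compound 1 to compound 3 (0.38 log units; beyond the scatter) and an at least 2.4-fold lower number from compound 2 to compound 3 (0.38 log units; beyond the scatter). Both give only a minimum size, and both are beyond the scatter. The third, a step that the two limits leave unreadable from compound 1 to compound 2, gives no size. Compound 1 and compound 2 both lack the group that compound 3 carries, and neither gives a number. Compound 4 lacks it too, and its cyclopentyl is closest in kind to the cyclopropyl of compound 1.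

A move to a higher number in this assay is therefore expected, and compound 4 may well be reported only as a limit. The expected step is a 2.4-fold higher number from compound 3 to compound 4 (0.39 log units; beyond the scatter). For compound 4 the estimated value is 100000 nM, with an expected range of 45000 nM to 220000 nM.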

Compound 4, half-maximal inhibitory concentration: > 100000 nM
Compound 4 gave a limit, no number; the forecaster's own chance of this, stated with the estimate: 70%; the middle value lies on the limit itself.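

In this assay, replacing the group of compound 3 with cyclopentyl on the amide-type nitrogen gives an at least 2.4-fold higher number from compound 3 to compound 4 (0.38 log units; beyond the scatter). Among these compounds, compound 4 gives > 100000 nM, a limit of the assay and not a number, so this step has a minimum size only and is the first step read in this direction, away from the group of compound 3. A ring of five carbons on the amide-type nitrogen, larger than the cyclopropyl of compound 1, does not bring the series off the limit, and compound 3 remains the only member with a number: the limit of > 100000 nM in this assay, at which 3 of the 4 values shown sit.

From the compounds shown here alone, the steps linking compound 4 to compound 1 and to compound 2 cannot be read, so any difference among cyclopropyl, cyclopentyl and piperidin-1-yl on the shared core remains open. Also open, going by these compounds, is whether the number of compound 3 goes with the nitrogen and oxygen of its six-membered ring or with the ring and its methyl groups alone, a question that cyclohexyl, or the same ring carrying a plain secondary amine, on the amide-type nitrogen would address.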